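Butyl amide replaces the thiophene amide on a shared core

The compounds below may be only part of what the source reports. "The series", "measured", "known", "first", "only" and "open" are said of these compounds alone.

Two amides of one core have been measured. Compound 1 `CN1CCC(c2c[nH]c3ccc(NC(=O)c4ccc([N+](=O)[O-])cc4)nc23)CC1` gives 7.7 nM in an assay for binding affinity to 5-hydroxytryptamine receptor 1F (Homo sapiens), read by radioligand binding (a lower number here means a stronger inhibitor, a higher number a weaker inhibitor), and compound 2 `CN1CCC(c2c[nH]c3ccc(NC(=O)c4cccs4)nc23)CC1` gives 7.1 nM. Compound 2 carries the lower of these two numbers, yet the step of a 1.1-fold lower number from compound 1 to compound 2 (0.04 log units; within the scatter) lies within the scatter. Compound 3 `CCCCC(=O)Nc1ccc2[nH]cc(C3CCN(C)CC3)c2n1` differs from compound 2 by butyl in place of thiophen-2-yl on a carbonyl carbon. Among the compounds with values here, the only measured step swaps one aromatic ring for another, so no measured step bears directly on an aromatic-to-chain exchange. Compound 3 is therefore expected to shift by a 2.8-fold higher number from compound 2 to compound 3 (0.45 log units; beyond the scatter), toward a somewhat higher number, giving an estimate of 20 nM with a range from 5 nM to 80 nM.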

Compound 3, inhibition constant: 14 nM
Compound 3: middle estimate off by 1.4-fold (0.15 log units), on the high side, and the stated range covers the measured number.
By their numbers in this assay, from the lowest: compounds 2, 1 and 3 (each within the scatter of the next).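

With butyl on the carbonyl carbon, a group with no ring takes the place of the aromatic rings carried by compound 1 and compound 2. In this assay, neither exchange can be told from the scatter: a 2.0-fold higher number from compound 2 to compound 3 (0.29 log units; within the scatter) and a 1.8-fold higher number from compound 1 to compound 3 (0.26 log units; within the scatter). So at this position, the presence of an aromatic ring is not needed to keep the number within the scatter of the two aromatic amides, and nothing available explains this result.

As far as these compounds go, it remains open whether a longer chain, a terminal amine or a carboxylic acid on the butyl chain would also stay within that scatter.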